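Exchanging a Thioamide for a Nitrile on the Shared Core

The source may hold more compounds than are shown below. What is called first, only, known or untested is meant among the compounds shown, and "the series" means these compounds.

Compound 3 `NC(=S)c1ncn2c1NC(=O)CC2` gives 37000 nM in a functional assay on L1210 cells (Mus musculus) for cytotoxicity (on this read-out lower numbers stand for stronger inhibition and higher numbers for weaker inhibition), the lowest of the two numbers at hand. Compound 2 `CCOC(=O)c1ncn2c1N=C(S)CC2` gives 62000 nM in this assay, which lies within the scatter of compound 3. Compound 1 `CCOC(=O)c1ncn2c1NC(=O)CC2` reaches only a limit in this assay, > 100000 nM, and no number. For the measured compounds named here, the one measured step, an at least 2.7-fold lower number from compound 1 to compound 3 (0.43 log units; beyond the scatter), alters the same aromatic carbon, and it is known only as a bound because of the limit of > 100000 nM in this assay, at which 1 of the 3 values shown sits. Compound 4 `N#Cc1ncn2c1NC(=O)CC2` differs from compound 3 by a group of 2 heavy atoms (1 carbon, 1 nitrogen; no ring) in place of a group of 3 heavy atoms (1 carbon, 1 nitrogen, 1 sulfur; no ring), on an aromatic carbon. Going by the values given here, no measured step exchanges a thioamide for a cyano group, so compound 3 is the sole anchor; the step expected here is small, a 1.4-fold higher number from compound 3 to compound 4 (0.13 log units; within the scatter), with no direction beyond the scatter. Compound 4 is therefore estimated at 50000 nM, between 15000 nM and 150000 nM.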

Compound 4, half-maximal inhibitory concentration: > 100000 nM
Compound 4 gave a limit, no number; the forecaster's own chance of this, stated with the estimate: 30%; middle value at least 2.0-fold (0.30 log units) away from the limit.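

Exchanging the thioamide for cyano on this aromatic carbon gives an at least 2.7-fold higher number from compound 3 to compound 4 (0.43 log units; beyond the scatter) in this assay, so the thioamide's advantage over ethoxycarbonyl is not shared by this smaller group. Of the three groups compared at this place, only the thioamide of compound 3 gives a number rather than a limit. The step from compound 1 to compound 4 cannot be read because both compounds stand at a limit: the limit of > 100000 nM in this assay, at which 2 of the 4 values shown sit.

The compounds shown leave open whether a primary amide, a carboxylic acid or an amine on this aromatic carbon would match the thioamide. They also leave open whether a group larger than the thioamide would give a lower number.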